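Swapping the pyridyl ring on the oxazole core

The source may hold more compounds than are shown below. What is called first, only, known or untested is meant among the compounds shown, and "the series" means these compounds.

Measured compounds:
- compound 1 `O=C(CCc1ccc(-c2ccccc2)cc1)c1ncc(-c2ccncc2)o1`: 2.3 nM
- compound 2 `O=C(CCc1ccc(Oc2ccccc2)cc1)c1ncc(C(F)(F)F)o1`: 2 nM
- compound 3 `O=C(O)c1cccc(-c2cnc(C(=O)CCc3ccc(-c4ccc(CN5CCCC5)cc4)cc3)o2)n1`: 130 nM

All three compounds were tested in an assay for inhibition of Fatty-acid amide hydrolase 1 (Rattus norvegicus); a higher number here means a weaker inhibitor, a lower number a stronger inhibitor. Compound 1 stands second highest of the three numbers. Its nearest neighbour is compound 2, whose number is lower by a gap that lies within the usual scatter, so the two cannot be ranked against each other. Its furthest neighbour is compound 3, whose number is far higher, well beyond the scatter; compound 3 differs from compound 1 in more than one place, so its two values are simply two points and not a single step.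

The unmeasured compound 4 `COC(=O)c1cccc(-c2cnc(C(=O)CCc3ccc(-c4ccccc4)cc3)o2)n1` is reached from compound 1 by one change: 6-(methoxycarbonyl)pyridin-2-yl in place of pyridin-4-yl on an aromatic carbon

Within the data shown here, no measured pair shows this exact change, so the expectation rests on the spread of the three numbers. Compound 3 carries a related acid on the same ring and sits much higher than compound 1, while compound 4 carries the methyl ester and keeps the plain biphenyl of compound 1. The step from compound 1 to compound 4 is expected to be small, a 1.3-fold higher number from compound 1 to compound 4 (0.12 log units; within the scatter), not clearly beyond the scatter in either direction. Compound 4 is therefore estimated at 3 nM, with a likely range from 0.6 nM to 15 nM.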

Compound 4, inhibition constant: 1.2 nM
Compound 4: middle estimate off by 2.5-fold (0.40 log units), on the high side; measured number inside the range.
By their numbers in this assay, from the lowest: compounds 4, 2 and 1 (each within the scatter of the next); then compound 3.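

Among these compounds, compound 1 and compound 4 are the first pair here that differ in only one place, so this is the first direct reading of a change at this position, next to the ring oxygen. In this assay, the step is a 1.9-fold lower number from compound 1 to compound 4 (0.28 log units; within the scatter), which means that the larger 6-(methoxycarbonyl)pyridin-2-yl group, with its extra carbon and oxygen atoms and its ester, can stand in place of pyridin-4-yl with no difference that can be told from scatter. Nothing measured here explains why the number holds across this swap.

The swap also alters two things together, the point at which the pyridine ring is attached and the presence of the ester, so a plain pyridin-2-yl group would be needed to show what each contributes. The high number of compound 3 (130 nM) also remains unassigned, since that compound carries both a carboxylic acid and a pyrrolidine, and only a compound with the carboxylic acid in place of the methyl ester on the otherwise unchanged compound 4 could show what the acid does alone.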